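The source may report more compounds than this note shows. Statements on the series, on what has been measured and on what is new or still open speak of the compounds shown alone.

The three measured compounds share one core and differ only in the substituent on an aromatic nitrogen. Compound 1 `O=C1c2c[n+]([O-])c3ccccc3c2C(=O)c2c1c1ccccc1n2Cc1cn([C@@H]2C[C@H](O)[C@@H](CO)O2)nn1` gives 120 nM in a functional assay on A549 cells (Homo sapiens) for cytotoxicity, read by MTT assay, with a stated time of 72 h; on this read-out lower numbers stand for stronger inhibition and higher numbers for weaker inhibition. Compound 2 `CC1(C)OCC(Cn2cc(Cn3c4c(c5ccccc53)C(=O)c3c[n+]([O-])c5ccccc5c3C4=O)nn2)O1` gives 80 nM, and compound 3 `CN1CCN(CCCCn2c3c(c4ccccc42)C(=O)c2c[n+]([O-])c4ccccc4c2C3=O)CC1` gives 90 nM. Among the compounds with values here, the single one-point step among them, a 1.5-fold lower number from compound 1 to compound 2 (0.18 log units; within the scatter), lies within the scatter. Compound 3 stands second highest of the three numbers; it is nearest to compound 2 and furthest from compound 1, and both gaps lie within the scatter, so the three compounds cannot be placed in any order.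

Compound 4 `CN(C)CCCCn1c2c(c3ccccc31)C(=O)c1c[n+]([O-])c3ccccc3c1C2=O` differs from compound 3 in one place: dimethylamino in place of 4-methylpiperazin-1-yl on a saturated chain carbon, four bonds along the chain from an aromatic nitrogen. Within the data shown here, no measured step touches this part of the chain; the only step available, from compound 1 to compound 2, alters the group directly on the aromatic nitrogen and is itself within the scatter. The measured compounds therefore give no ground for expecting a step in this assay beyond the scatter in either direction, and a step of about a 1.1-fold higher number from compound 3 to compound 4 (0.05 log units; within the scatter) is expected. For compound 4 the estimated value in this assay is 100 nM, with a range from 45 nM to 220 nM.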

Compound 4, half-maximal inhibitory concentration: 310 nM
Compound 4: the middle estimate sits 3.1-fold (0.49 log units) below what was measured; the whole stated range lies below it.
By their numbers in this assay, from the lowest: compounds 2, 3 and 1 (each within the scatter of the next); then compound 4.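

In this assay the exchange of 4-methylpiperazin-1-yl for dimethylamino gives a 3.4-fold higher number from compound 3 to compound 4 (0.54 log units; beyond the scatter), the only step among the compounds shown that goes beyond the scatter. Within the data shown here, the one earlier step altered the group directly on the aromatic nitrogen and stayed within the scatter, whereas this pair shows that the number does respond to the group on a saturated chain carbon, four bonds along the chain from an aromatic nitrogen, and that here the smaller, ring-free dimethylamino group goes with the higher number, which stands for weaker inhibition. Nothing measured on these compounds bears on why the number moves, so the step stands as an observation without an explanation.

A single pair cannot tell whether the ring or the second ring nitrogen of 4-methylpiperazin-1-yl is what matters, and a piperidin-1-yl or morpholin-4-yl group at this place would begin to separate the two. It also leaves open whether the same exchange gives a step of similar size on a shorter or longer chain, or whether a primary amine at the chain end would follow dimethylamino.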